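Ring Swap Repeated on a Shorter-Chain Core

The source may report more compounds than this note shows. Statements on the series, on what has been measured and on what is new or still open speak of the compounds shown alone.

Compound 1, `CCCCCCCCCCCCCCCCOP(=O)(O)OCCSC(=S)N1CCCCCC1`: 32100 nM
Compound 2, `CCCCCCCCCCCCCCCCOP(=O)(O)OCCSC(=S)N1CCN(C)CC1`: 95200 nM
Compound 3, `CCCCCCCCOP(=O)(O)OCCSC(=S)N1CCN(C)CC1`: given only as a limit, > 100000 nM

These three compounds were tested in a functional assay on PC-3 cells (Homo sapiens) for inhibition, read by MTT assay, with stated times of 18 h and 4 h; a lower number here means a stronger inhibitor, a higher number a weaker inhibitor. Compound 1 and compound 2 share the same long-chain core and differ at one point: azepan-1-yl in place of 4-methylpiperazin-1-yl on a thiocarbonyl carbon. That change gave a 3.0-fold lower number from compound 2 to compound 1 (0.47 log units; beyond the scatter). Compound 3 carries the same group as compound 2 but on a different core; the two cores differ in that (hydrogen in place of octyl on a saturated chain carbon, eight bonds along the chain from an oxygen on an unsaturated carbon). In this assay compound 3 reaches only a limit of the assay, the one set at the limit of > 100000 nM in this assay, at which 1 of the 3 values shown sits. The step from the longer to the shorter core reads an at least 1.0-fold higher number from compound 2 to compound 3 (0.02 log units; that floor lies within the scatter).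

Compound 4, `CCCCCCCCOP(=O)(O)OCCSC(=S)N1CCCCCC1`, has not yet been measured. It differs from compound 3 in that (azepan-1-yl in place of 4-methylpiperazin-1-yl on a thiocarbonyl carbon), the same change, at the same place, as from compound 2 to compound 1, now made on the shorter-chain core. If that change behaves as it did before, compound 4 is expected to show a step of an at least 1.2-fold lower number from compound 3 to compound 4 (0.09 log units; that floor lies within the scatter), resting on a 3.0-fold lower number from compound 2 to compound 1 (0.47 log units; beyond the scatter). Compound 4 is therefore estimated at 80000 nM, likely between 30000 nM and 250000 nM. Because compound 3 sits at the limit of > 100000 nM in this assay, at which 1 of the 3 values shown sits, compound 4 may well be reported only as a limit again.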

Compound 4, half-maximal inhibitory concentration: 56800 nM
Estimate against measurement, compound 4: 1.4-fold (0.15 log units) above; low and high end bracket the measured number.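

With azepan-1-yl in place of 4-methylpiperazin-1-yl on the shorter-chain core, this assay shows an at least 1.7-fold lower number from compound 3 to compound 4 (0.24 log units; that floor lies within the scatter). This points the same way as on the longer-chain core, but the floor of this step does not by itself clear the usual scatter. Compound 3 is given only as a limit of the assay, so the true size of the step stays unknown, and the change cannot be called equal or unequal on the two cores: the same change on two cores in this assay, a 3.0-fold lower number (0.47 log units; beyond the scatter) from compound 2 to compound 1 and an at least 1.7-fold lower number (0.24 log units; that floor lies within the scatter) from compound 3 to compound 4; the limit leaves it open whether they differ Between the two azepan-1-yl compounds, shortening the chain gives a 1.8-fold higher number from compound 1 to compound 4 (0.25 log units; within the scatter), so this pair shows no clear effect of the chain, and the two chain steps cannot be told apart: the same change on two cores in this assay, an at least 1.0-fold higher number (0.02 log units; that floor lies within the scatter) from compound 2 to compound 3 and a 1.8-fold higher number (0.25 log units; within the scatter) from compound 1 to compound 4; the limit leaves it open whether they differ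

The compounds shown leave open whether the ring swap would hold on a chain longer than that of compound 1. They also leave open how a morpholine ring or a piperidine ring in the same place on the thiocarbonyl carbon would compare with these two rings.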